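Removing the phenyl from a diazepane ring: an expectation

The source may report more compounds than this note shows. Statements on the series, on what has been measured and on what is new or still open speak of the compounds shown alone.

Measured so far:
compound 1 `N#Cc1ccc(Cn2cncc2CN2CCCN(C(=O)c3cccs3)CC2)cc1` with 4%
compound 2 `CC(C)CC(=O)N1CCCN(Cc2cncn2Cc2ccc(C#N)cc2)CC1` with 13%
compound 3 `N#Cc1ccc(Cn2cncc2CN2CCC(c3ccccc3)N(C(=O)C3CCCCC3)CC2)cc1` with 5%

All three compounds were tested in a functional assay on PC-3 cells (Homo sapiens) for antiproliferative activity, read by MTT assay, with a stated time of 72 h, tested at 100 uM; a higher number here means more inhibition at the concentration tested (going by the name of the read-out), a lower number less inhibition. Every one of them gives a low reading, and the differences between them are within the usual scatter of repeated measurements. Going by the values given here, the only step measured between two compounds that differ in one place is a number 9 percentage points higher from compound 1 to compound 2 (within the scatter), which concerns the group on the carbonyl carbon and not the ring itself. Compound 3 sits between compound 1 and compound 2 on the numbers, closest to compound 1, and neither gap is beyond the scatter.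

Compound 4 `N#Cc1ccc(Cn2cncc2CN2CCCN(C(=O)C3CCCCC3)CC2)cc1` has not yet been measured. It differs from compound 3 in one place: hydrogen in place of phenyl on a saturated ring carbon. Among the compounds with values here, no measured step touches this kind of change, so nothing in the data speaks for a large move in either direction, and the low readings of compound 1 and compound 3 give no sign that the phenyl matters much. The step is expected to be a number 1 percentage points higher from compound 3 to compound 4 (within the scatter), that is, no move beyond the scatter. Compound 4 is therefore estimated to give 6%, with a range from 0% to 16%.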

Compound 4, a percentage reported as inhibition, at one concentration (the size of the read-out at that concentration, not a potency): 20%
Estimate against measurement, compound 4: 14 percentage points below; measured number outside the range, above it.
By their numbers in this assay, from the lowest: compounds 1, 3, 2 and 4 (each within the scatter of the next, the first and the last beyond it).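

In this assay, the saturated ring carbon next to the ring nitrogen now has a measured step of its own: hydrogen in place of phenyl gives a number 15 percentage points higher from compound 3 to compound 4 (beyond the scatter) and so goes beyond the scatter, which shows that the phenyl at this position does not leave the reading unchanged. With hydrogen on that carbon, the group on the carbonyl carbon also shows a step beyond the scatter, since cyclohexyl in place of thiophen-2-yl gives a number 16 percentage points higher from compound 1 to compound 4 (beyond the scatter), whereas cyclohexyl in place of isobutyl gives only a number 7 percentage points higher from compound 2 to compound 4 (within the scatter) and stays within it. Nothing measured here says why the reading rises when the phenyl leaves.

The compounds shown leave open whether only the phenyl lowers the reading or whether a small group on the same carbon, such as a methyl or a hydroxyl, would do the same. They also leave open whether the step from phenyl to hydrogen would be repeated with isobutyl or thiophen-2-yl in place of cyclohexyl on the carbonyl carbon.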